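The source may report more compounds than this note shows. Statements on the series, on what has been measured and on what is new or still open speak of the compounds shown alone.

Measured so far in a functional assay on A-375 cells (Homo sapiens) for inhibition, read by CCK-8 assay, with a stated time of 72 h, tested at 2 uM; on this read-out lower numbers stand for less inhibition of growth and higher numbers for more inhibition of growth at the one concentration tested:
compound 1 `COc1ccc(SCc2ccc(/C=C/C(=O)Nc3ccccc3N)cc2)cc1OC`: 46%
compound 2 `Nc1ccccc1NC(=O)c1ccc(CSc2nccc(C(F)(F)F)n2)cc1`: 54.4%

Of the two numbers, compound 1 gives the smaller in this assay, 46%, but its nearest neighbour, compound 2 with 54.4%, differs only within the usual scatter, so the two compounds cannot be told apart on these results.

Compound 3 `Nc1ccccc1NC(=O)/C=C/c1ccc(CSCCc2ccccc2)cc1` has not yet been measured. It differs from compound 1 in one place: phenethyl in place of 3,4-dimethoxyphenyl on a sulfur. Among the measured compounds shown here, no pair of measured compounds differs in a comparable single change, so there is no measured step from which the size of this one could be read off. With only the value of compound 1 to go on, the step from compound 1 to compound 3 is expected to stay within the scatter, with no clear direction: a number 1 percentage points lower from compound 1 to compound 3 (within the scatter). Compound 3 is therefore estimated at 45%, in a range from 25% to 65%.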

Compound 3, percent growth inhibition at one concentration: 41.9%
The estimate for compound 3 lay 3.1 percentage points above the measured number; low and high end bracket the measured number.
By their numbers in this assay, from the lowest: compounds 3, 1 and 2 (each within the scatter of the next, the first and the last beyond it).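

In this assay, the group on the sulfur now has its first measured step, with phenethyl in place of 3,4-dimethoxyphenyl (a number 4.1 percentage points lower from compound 1 to compound 3 (within the scatter)). At this position, then, a group containing oxygen can give way to one of carbon only, and the result cannot be told apart from that of compound 1. Nothing measured here bears on why the step is this small.

This single step combines the loss of the oxygens with the arrival of a saturated chain, so it cannot show what each change contributes alone. It also leaves open whether a different group on the sulfur, such as an amine, a carboxylic acid or a chain longer than phenethyl, would shift growth inhibition beyond the scatter.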